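A few compounds are considered here, and "the series" means these few. Any claim that something is new, unique, unknown or untested is made for them only; others in the source may bear on it.

Measured so far:
compound 1 `CC(C)C(Nc1nnc[nH]1)c1ccc(-c2ccc3cccc(F)c3c2)[nH]c1=O`, 22 nM
compound 2 `CC(C)C(c1ncc[nH]1)c1ccc(-c2ccc3cccc(F)c3c2)[nH]c1=O`, 7.3 nM

In an assay on CHO cells for displacement of a labelled ligand from prostaglandin E2 receptor EP3 subtype (Homo sapiens), read by radioligand binding (a higher number here means a weaker inhibitor, a lower number a stronger inhibitor), compound 2 gives 7.3 nM, the lowest of the two numbers, while compound 1 gives 22 nM, the change being a 3.0-fold lower number from compound 1 to compound 2 (0.48 log units; beyond the scatter). Compound 3 `CC(C)C(Cc1nnn[nH]1)c1ccc(-c2ccc3cccc(F)c3c2)[nH]c1=O` differs from compound 2 in one place: (1H-tetrazol-5-yl)methyl in place of 1H-imidazol-2-yl on a saturated chain carbon bound to an aromatic carbon and a saturated chain carbon. Among the measured compounds shown here, the single measured step, a 3.0-fold lower number from compound 1 to compound 2 (0.48 log units; beyond the scatter), altered the same position and was modest, but it exchanged a different pair of groups, so it guides only loosely. The step to compound 3 is therefore expected to be small, a 1.4-fold higher number from compound 2 to compound 3 (0.14 log units; within the scatter), with no clear direction beyond the scatter. Compound 3 is estimated at 10 nM, within 3 nM to 40 nM.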

Compound 3, inhibition constant: 34 nM
For compound 3 the middle estimate is 3.4-fold (0.53 log units) below the measured one; low and high end bracket the measured number.
By their numbers in this assay, from the lowest: compound 2; then compounds 1 and 3 (each within the scatter of the next).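

This position responds to the group it carries: (1H-tetrazol-5-yl)methyl in place of 1H-imidazol-2-yl moves the number beyond the scatter (a 4.7-fold higher number from compound 2 to compound 3 (0.67 log units; beyond the scatter)), so these two groups are not interchangeable here. Set against (4H-1,2,4-triazol-3-yl)amino, the same group makes no change that can be read (a 1.5-fold higher number from compound 1 to compound 3 (0.19 log units; within the scatter)), leaving 1H-imidazol-2-yl alone with the lowest number of the three. Nothing measured here explains this difference. Going by these compounds, whether a carboxylic acid or a simple amine on this saturated chain carbon would match compound 2 remains open.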